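Branching the Short Arm of a Diyne Diol

This account rests on a few compounds, and the source may have more. Where it says the series, first, only, none or still open, it means among the compounds named here.

Measured so far:
compound 1 `CCCC(O)C#CC#CCO` — a limit of the assay, > 50000 nM
compound 2 `CCCCCC(O)C#CC#CC(O)CCC` — 19000 nM
compound 3 `CCCCCCCCCC(O)C#CC#CC(O)CCCCC` — 12000 nM

In a toxicity assay on Hepa-1c1c7 cells (Mus musculus) for inhibition (on this read-out higher numbers stand for weaker inhibition and lower numbers for stronger inhibition), compound 2 holds the highest of the two numbers; the nearest is a 1.6-fold lower number from compound 2 to compound 3 (0.20 log units; within the scatter), within the scatter. The value of compound 1 is a limit of this assay (the limit of > 50000 nM in this assay, at which 1 of the 3 values shown sits). Compound 4 `CCCCCC(O)C#CC#CC(O)CC(C)C` differs from compound 2 by methyl in place of hydrogen on a saturated chain carbon bound to two saturated chain carbons. Within the data shown here, two measured steps bear on it: an at least 2.6-fold lower number from compound 1 to compound 2 (0.42 log units; beyond the scatter), at least modest, and a 1.6-fold lower number from compound 2 to compound 3 (0.20 log units; within the scatter), within the scatter. Both add far larger chains than a methyl, so a step beyond the scatter is not expected. Compound 4 is estimated at 17000 nM, between 8000 nM and 40000 nM, an expected 1.1-fold lower number from compound 2 to compound 4 (0.05 log units; within the scatter).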

Compound 4, half-maximal inhibitory concentration: 41000 nM
Compound 4: middle estimate off by 2.4-fold (0.38 log units), on the low side; the measured number lies above the stated range.
By their numbers in this assay, from the lowest: compounds 3 and 2 (each within the scatter of the next); then compound 4. At a limit, above all of these: compound 1.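

In this assay, the change from propyl to isobutyl gives a 2.2-fold higher number from compound 2 to compound 4 (0.33 log units; beyond the scatter), the only step shown that raises the number beyond the scatter. The earlier steps shown here added pentyl and hexyl, and neither raised it, so at this position adding carbon does not by itself bring a lower number. Compound 1 alone remains at a limit of the assay: the limit of > 50000 nM in this assay, at which 1 of the 4 values shown sits.

The compounds shown leave open whether the rise follows from the branch itself or from the added carbon. They also leave open how an ethyl or an amine on the same carbon would read.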